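The source may report more compounds than this note shows. Statements on the series, on what has been measured and on what is new or still open speak of the compounds shown alone.

Measured so far in a functional assay on MCF7 cells (Homo sapiens) for antiproliferative activity, read by MTT assay, with a stated time of 48 h; on this read-out higher numbers stand for weaker inhibition and lower numbers for stronger inhibition:
- compound 1 `C=C(c1ccc2c(c1)C=CC(C)(C)O2)c1ccc(OC)cc1NC(=O)CO`: 390 nM
- compound 2 `C=C(c1ccc2c(c1)C=CC(C)(C)O2)c1ccc(OC)cc1NC(=O)CN`: 420 nM
- compound 3 `C=C(c1ccc2c(c1)C=CC(C)(C)O2)c1ccc(OC)cc1NC(=O)CNC`: 720 nM

All three compounds share one core and differ only in the group on the saturated chain carbon bound to the carbonyl carbon. Compound 3 gives 720 nM, which lies within the usual scatter of both other values.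

The next compound is compound 4 `C=C(c1ccc2c(c1)C=CC(C)(C)O2)c1ccc(OC)cc1NC(=O)CNCC`. Its change is methyl in place of hydrogen on a saturated chain carbon bound to an amine nitrogen, so methylamino becomes ethylamino.

The closest measured change also adds a methyl, but on the amine nitrogen, giving a 1.7-fold higher number from compound 2 to compound 3 (0.23 log units; within the scatter). The other two steps are a 1.1-fold higher number from compound 1 to compound 2 (0.03 log units; within the scatter) and a 1.8-fold higher number from compound 1 to compound 3 (0.27 log units; within the scatter). None of these left the scatter, so only a small shift, if any, is expected in this assay, perhaps towards a slightly higher number.

The estimated step is a 1.1-fold higher number from compound 3 to compound 4 (0.05 log units; within the scatter).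

For compound 4 the estimated value is 800 nM, with an expected range from 380 nM to 1700 nM.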

Compound 4, half-maximal inhibitory concentration: 3370 nM
Compound 4: the middle estimate sits 4.2-fold (0.62 log units) below what was measured; the whole stated range lies below it.
By their numbers in this assay, from the lowest: compounds 1, 2 and 3 (each within the scatter of the next); then compound 4.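

In this assay, among these compounds, the methyl placed on a saturated chain carbon bound to an amine nitrogen, which turns methylamino into ethylamino, gives the first step to go beyond the scatter, with a 4.7-fold higher number from compound 3 to compound 4 (0.67 log units; beyond the scatter). The gap also holds against the other two compounds, with an 8.0-fold higher number from compound 2 to compound 4 (0.90 log units; beyond the scatter) and an 8.6-fold higher number from compound 1 to compound 4 (0.94 log units; beyond the scatter), so this end of the molecule tolerates hydroxy, amino and methylamino but not ethylamino on the same core. Nothing available explains why this one small addition matters when the earlier swaps did not.

The compounds shown leave open whether a propylamino group would raise the number further or whether the rise is particular to ethylamino. A dimethylamino group would show whether the outcome depends on where the added carbon sits.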